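The source may hold more compounds than are shown below. What is called first, only, known or untested is meant among the compounds shown, and "the series" means these compounds.

Measured compounds:
Compound 1, `O=C(Nc1cccc(-c2oc3cc(-c4ccc(F)cc4)ccc3c(=O)c2O)c1)c1ccc(F)cc1F`, in a functional assay on HepG2 cells (Homo sapiens) for antiproliferative activity, read by CCK-8 assay, with a stated time of 72 h; on this read-out higher numbers stand for weaker inhibition and lower numbers for stronger inhibition: 26400 nM.
Compound 2, `O=C(Nc1cccc(-c2oc3cc(-c4ccc(F)cc4)ccc3c(=O)c2O)c1)c1ccc(C(F)(F)F)cc1`: 42700 nM.
Compound 3, `Cc1cccc(C(=O)Nc2cccc(-c3oc4cc(-c5ccc(F)cc5)ccc4c(=O)c3O)c2)c1`: 13500 nM.

Compound 3 has the lowest of the three numbers in this assay. The step of a 2.0-fold lower number from compound 1 to compound 3 (0.29 log units; within the scatter) lies within the scatter, whereas the step of a 3.2-fold lower number from compound 2 to compound 3 (0.50 log units; beyond the scatter) lies beyond it, so compound 3 is separated clearly only from compound 2.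

Compound 4, `COc1cc(OC)cc(C(=O)Nc2cccc(-c3oc4cc(-c5ccc(F)cc5)ccc4c(=O)c3O)c2)c1`, has not been measured. It differs from compound 3 by 3,5-dimethoxyphenyl in place of 3-methylphenyl on a carbonyl carbon. The three measured steps all exchange the aryl group on that same carbonyl carbon: a 1.6-fold higher number from compound 1 to compound 2 (0.21 log units; within the scatter), a 2.0-fold lower number from compound 1 to compound 3 (0.29 log units; within the scatter) and a 3.2-fold lower number from compound 2 to compound 3 (0.50 log units; beyond the scatter). Among the measured compounds shown here, none of them introduces a methoxy group, so there is no direct precedent for the entering group. These steps were small to modest in either direction, and a step of similar size is expected here: the estimated step is a 1.1-fold higher number from compound 3 to compound 4 (0.05 log units; within the scatter). Compound 4 is therefore estimated to give 15000 nM in this assay, with a range from 6000 nM to 40000 nM.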

Compound 4, half-maximal inhibitory concentration: 23500 nM
Compound 4: the middle estimate sits 1.6-fold (0.19 log units) below what was measured, within the range that was stated.
By their numbers in this assay, from the lowest: compounds 3, 4, 1 and 2 (each within the scatter of the next, the first and the last beyond it).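

Among the compounds shown, only compound 4 carries oxygen on the aryl group at the carbonyl carbon, and in this assay all three of its steps lie within the scatter (a 1.7-fold higher number from compound 3 to compound 4 (0.24 log units; within the scatter); a 1.8-fold lower number from compound 2 to compound 4 (0.26 log units; within the scatter); a 1.1-fold lower number from compound 1 to compound 4 (0.05 log units; within the scatter)). Compound 4 therefore cannot be separated from any of the other three compounds, so 3,5-dimethoxyphenyl adds a fourth aryl group at this position while the only gap beyond the scatter remains that between compound 2 and compound 3. Nothing shown here gives a reason for this result.

The compounds leave open whether one methoxy group alone would read like the pair in 3,5-dimethoxyphenyl. They also leave open whether a morpholine, a carboxylic acid or a longer alkyl chain in place of the aryl group would give a step beyond the scatter.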